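The source may hold more compounds than are shown below. What is called first, only, known or untested is meant among the compounds shown, and "the series" means these compounds.

Compound 1 `CCCn1nc(-c2cccnc2)c2ccccc2c1=O`: 86%
Compound 2 `CCCCCCCCn1nc(-c2cccnc2)c2ccccc2c1=O`: 99%
Compound 3 `O=c1c2ccccc2c(-c2cccnc2)nn1C1CCCC1`: 97%

Of the compounds shown here, three sharing one core have been measured in an assay on isolated protein (Oryctolagus cuniculus) with Thromboxane-A synthase (Homo sapiens) as the target, tested at 1 uM; on this read-out higher numbers stand for more inhibition at the one concentration tested (going by the name of the read-out) and lower numbers for less inhibition. Compound 1 stands lowest of the three: in this assay compound 1 gives 86%, while compound 2 gives 99% and compound 3 gives 97%. Compound 4 `O=c1c2ccccc2c(-c2cccnc2)nn1CC1CCCCC1` has not yet been measured; it differs from compound 1 by cyclohexyl in place of ethyl on a saturated chain carbon bound to an aromatic nitrogen.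

Going by the values given here, two measured steps bear on this change, both starting from compound 1 and both making the group on the aromatic nitrogen larger. The first, a number 13 percentage points higher from compound 1 to compound 2 (beyond the scatter), lengthens the chain. The second, a number 11 percentage points higher from compound 1 to compound 3 (beyond the scatter), exchanges the propyl for a ring. Between the two larger groups the numbers hardly move: a number 2 percentage points lower from compound 2 to compound 3 (within the scatter). A modest upward step in this assay is therefore expected for compound 4, of about a number 10 percentage points higher from compound 1 to compound 4 (within the scatter). Compound 4 is estimated to give 96% in this assay, within a range from 88% to 100%.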

Compound 4, a percentage reported as inhibition, at one concentration (the size of the read-out at that concentration, not a potency): 98%
Compound 4: the middle estimate sits 2 percentage points below what was measured; measured number inside the range.
By their numbers in this assay, from the lowest: compound 1; then compounds 3, 4 and 2 (each within the scatter of the next).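

Cyclohexylmethyl on the aromatic nitrogen also gives a higher number than propyl in this assay, with a number 12 percentage points higher from compound 1 to compound 4 (beyond the scatter) as the step, so this rise is now seen with a third larger group. Compound 4 cannot be separated from the other two, with a number 1 percentage points higher from compound 3 to compound 4 (within the scatter) and a number 1 percentage points lower from compound 2 to compound 4 (within the scatter) as the steps, so a ring on a saturated chain carbon, a ring directly on the nitrogen and a long open chain read alike at this one concentration. Nothing available explains why these larger groups read higher than propyl.

From the compounds shown here alone, all the groups at this position contain only carbon and hydrogen, so how an amine or a carboxylic acid would read there remains open. Also open, going by these compounds, is whether a methyl group would read lower than the propyl of compound 1.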